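Chloro for Bromo on the Triazole Aryl Group

This account rests on a few compounds, and the source may have more. Where it says the series, first, only, none or still open, it means among the compounds named here.

Compound 2 `C=C1C(=O)[C@]23C[C@@]1(O)CC[C@H]2c1ccc(OS(=O)(=O)c2ccc(C)cc2)c(C)c1[C@@H]3Cn1cc(-c2ccc(Br)cc2)nn1` gives 1020 nM in a functional assay on HL-60 cells (Homo sapiens) for cytotoxicity, read by MTT assay, with a stated time of 4 days (a higher number here means a weaker inhibitor, a lower number a stronger inhibitor), one of two numbers in hand; compound 1 `C=C1C(=O)[C@]23C[C@@]1(O)CC[C@H]2c1ccc(OS(=O)(=O)c2ccc(C)cc2)c(C)c1[C@@H]3Cn1cc(-c2ccccn2)nn1` gives 1810 nM, and the change a 1.8-fold lower number from compound 1 to compound 2 (0.25 log units; within the scatter) lies within the scatter. Compound 3 `C=C1C(=O)[C@]23C[C@@]1(O)CC[C@H]2c1ccc(OS(=O)(=O)c2ccc(C)cc2)c(C)c1[C@@H]3Cn1cc(-c2ccc(Cl)cc2)nn1` differs from compound 2 by chloro in place of bromo on an aromatic carbon. Going by the values given here, no measured step exchanges one halogen for another; the only step available swapped whole aryl groups on the triazole and moved little. Compound 3 is therefore expected to shift by no more than the scatter, a 1.1-fold higher number from compound 2 to compound 3 (0.03 log units; within the scatter), with an estimated 1100 nM in this assay, between 500 nM and 2500 nM.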

Compound 3, half-maximal inhibitory concentration: 1260 nM
Compound 3: middle estimate off by 1.1-fold (0.06 log units), on the low side, within the range that was stated.
By their numbers in this assay, from the lowest: compounds 2, 3 and 1 (each within the scatter of the next).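

In this assay, chloro in place of bromo on the aromatic ring gives a 1.2-fold higher number from compound 2 to compound 3 (0.09 log units; within the scatter), so the only halogen exchange shown at this position stays within the scatter. Replacing pyridin-2-yl with 4-chlorophenyl gives a 1.4-fold lower number from compound 1 to compound 3 (0.16 log units; within the scatter), which also stays within the scatter, so this read-out does not separate compound 1, compound 2 and compound 3. Nothing available explains these small differences.

The compounds shown leave open whether an amine, a carboxylic acid or a methoxy group at this position would move the number beyond the scatter. They also leave open how an unsubstituted phenyl would compare with the two halogenated rings.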